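Ring-to-chain swap at the oxadiazole substituent

The source may hold more compounds than are shown below. What is called first, only, known or untested is meant among the compounds shown, and "the series" means these compounds.

Measured so far:
compound 1, `O=C(NCc1ccc(-c2noc(C3CCCCCC3)n2)cc1)[C@H]1NCC[C@@H]1O`: 620 nM
compound 2, `O=C(NCc1ccc(-c2noc(C3CCCCC3)n2)cc1)[C@H]1NCC[C@@H]1O`: 380 nM

In an assay on isolated protein for inhibition of sphingosine kinase 1 (Homo sapiens) (on this read-out lower numbers stand for stronger inhibition and higher numbers for weaker inhibition), compound 1 gives 620 nM and compound 2 gives 380 nM. The one measured step, a 1.6-fold lower number from compound 1 to compound 2 (0.21 log units; within the scatter), is within the scatter, so the two numbers cannot be ordered; compound 2 simply holds the lowest of the two numbers shown, with compound 1 as its nearest neighbour.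

Compound 3, `CCCCCc1nc(-c2ccc(CNC(=O)[C@H]3NCC[C@@H]3O)cc2)no1`, has not been measured in this assay. It differs from compound 2 in one place: pentyl in place of cyclohexyl on an aromatic carbon. For the measured compounds named here, the only step that bears on this change is the ring-size step from compound 1 to compound 2, which stayed within the scatter. Going by the values given here, no step here opens a ring into a chain, so the data give no direct guide to that part of the change.

Given this, compound 3 is expected to stay close to compound 2, with at most a modest shift toward a higher number, i.e. a 1.6-fold higher number from compound 2 to compound 3 (0.20 log units; within the scatter). The estimate for compound 3 in this assay is 600 nM, ranging from 200 nM to 1800 nM.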

Compound 3, half-maximal inhibitory concentration in the sphingosine kinase 1 assay: 430 nM
Compound 3: middle estimate off by 1.4-fold (0.14 log units), on the high side; measured number inside the range.
By their numbers in the sphingosine kinase 1 assay, from the lowest: compounds 2, 3 and 1 (each within the scatter of the next).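

In the sphingosine kinase 1 assay the swap of cyclohexyl for pentyl on the aromatic carbon gives a 1.1-fold higher number from compound 2 to compound 3 (0.05 log units; within the scatter) and, as the only ring-to-chain step shown, puts the open chain on the same footing as the six-membered ring at this position. The comparison with the larger ring gives a 1.4-fold lower number from compound 1 to compound 3 (0.16 log units; within the scatter) and so cycloheptyl, cyclohexyl and pentyl cannot be told apart on this read-out, which means that among these compounds a ring on this carbon is not needed to keep the number within the scatter. In a physicochemical assay for solubility, at pH 7.4 (a higher number here means a more soluble compound, a lower number a less soluble compound), compound 2 gives > 50 ug/mL as a limit of the assay and not a number. In the physicochemical assay compound 3 gives > 50 ug/mL as a limit of the assay and not a number. In the physicochemical assay the step from compound 2 to compound 3 cannot be read, as both compounds sit at the same limit of the assay: the limit of > 50 ug/mL in the physicochemical assay, at which 2 of the 2 values shown sit.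

Still open, from the compounds shown here alone, is whether a shorter chain such as propyl, a branched group such as tert-butyl, or a chain ending in an amine or a carboxylic acid would stay within the scatter of these three in the sphingosine kinase 1 assay as well. With only limit values shown in the physicochemical assay no ranking of the ring and the chain is possible on that read-out.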